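This account rests on a few compounds, and the source may have more. Where it says the series, first, only, none or still open, it means among the compounds named here.

Compound 1 `CCOC(=O)[C@]1(C(=O)Nc2ccccc2)C[C@H]1c1cc(OC)c(OC)c(OC)c1` and compound 2 `CCOC(=O)[C@@]1(C(=O)Nc2ccccc2)C[C@H]1c1cc(OC)c(OC)c(OC)c1` share every atom and bond and differ only in the configuration at one stereocentre. In a functional assay on A549 cells (Homo sapiens) for cytotoxicity, read by MTT assay, with a stated time of 48 h (a higher number here means a weaker inhibitor, a lower number a stronger inhibitor), compound 1 gives 37300 nM, and compound 2 gives 65900 nM. The step between them is a 1.8-fold higher number from compound 1 to compound 2 (0.25 log units; within the scatter), so on these numbers the two compounds cannot be told apart, and compound 2 has no other measured neighbour. Going by the values given here, compound 3 `CCOC(=O)[C@@]1(C(=O)Nc2ccccc2)C[C@@H]1c1cc(OC)c(OC)c(OC)c1` has not yet been measured. the two compounds have the same atoms and bonds and differ only in configuration as drawn: 1 of 2 stereo elements differ; a stereocentre at a saturated ring carbon is drawn S in compound 2 and R in compound 3 Only one measured step bears on this change: the step from compound 1 to compound 2, which rests on the same kind of difference (the fact that compounds 1 and 2 differ only in the configuration as drawn), a single stereocentre drawn the other way, and which stayed within the scatter. Compound 3 is therefore expected to lie close to compound 2 in this assay, and the expected step is a 1.3-fold lower number from compound 2 to compound 3 (0.12 log units; within the scatter), which is within the scatter. The estimate for compound 3 is 50000 nM, with a range from 20000 nM to 130000 nM.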

Compound 3, half-maximal inhibitory concentration: > 100000 nM
Compound 3 was reported as a limit (the forecaster's own chance of this, stated with the estimate: 10%); middle value at least 2.0-fold (0.30 log units) from the limit.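

In this assay compound 3 gives > 100000 nM, which is a limit of the assay and not a number. Going by these compounds alone, the step here is an at least 1.5-fold higher number from compound 2 to compound 3 (0.18 log units; that floor lies within the scatter), so only a floor is known, and that floor does not separate the two compounds, although the inversion is at a different stereocentre from the one that links compound 1 and compound 2. The other step is an at least 2.6-fold higher number from compound 1 to compound 3 (0.42 log units; beyond the scatter), the first in this set to pass beyond the scatter, and it is a change in which both stereocentres are inverted: the fact that compounds 1 and 3 differ only in the configuration as drawn

The compounds shown leave open how far compound 3 truly lies from compound 2, and where the mirror image of compound 2 would stand. They also leave open whether a carboxylic acid in place of the ethyl ester would keep the gap between the mirror images.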